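Formyl to Acetyl on the Shared Core

The source may report more compounds than this note shows. Statements on the series, on what has been measured and on what is new or still open speak of the compounds shown alone.

In a functional assay on A549 cells (Homo sapiens) for cytotoxicity, read by MTT assay, with a stated time of 48 h (a lower number here means a stronger inhibitor, a higher number a weaker inhibitor), compound 3 `Cc1ccccc1-c1nc2c(C=O)c(O)ccc2o1` gives 2210 nM, the lower of the two numbers shown. Compound 2 `O=Cc1c(O)ccc2oc(-c3ccccc3Cl)nc12` gives 7680 nM in this assay, and the change a 3.5-fold lower number from compound 2 to compound 3 (0.54 log units; beyond the scatter) is modest. Compound 1 `CC(=O)c1c(O)ccc2oc(-c3ccccc3)nc12` carries an acetyl rather than a formyl group and also differs from the other two elsewhere in the molecule; in this assay it reaches the limit > 30000 nM, and the limit of > 30000 nM in this assay, at which 1 of the 3 values shown sits, is where it sits. Compound 4 `CC(=O)c1c(O)ccc2oc(-c3ccccc3C)nc12` differs from compound 3 by methyl in place of hydrogen on a carbonyl carbon. Within the data shown here, no measured pair isolates this change: the only acetyl compound, compound 1, differs from compound 3 in two places at once, so its limit cannot be carried over to compound 4 directly. Compound 4 is expected to give a higher number than compound 3, with the step of a 4.1-fold higher number from compound 3 to compound 4 (0.61 log units; beyond the scatter) taken as an estimate of uncertain size. The estimate for compound 4 in this assay is 9000 nM, between 2500 nM and 35000 nM.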

Compound 4, half-maximal inhibitory concentration: 20100 nM
Compound 4: the middle estimate sits 2.2-fold (0.35 log units) below what was measured, and the stated range covers the measured number.
By their numbers in this assay, from the lowest: compound 3; then compound 2; then compound 4. At a limit, above all of these: compound 1.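

Compound 3 and compound 4 isolate the change from formyl to acetyl on this carbonyl carbon, with the rest of the molecule held constant, and in this assay the result is a 9.1-fold higher number from compound 3 to compound 4 (0.96 log units; beyond the scatter). The acetyl group does not by itself take a compound to the limit, since compound 4 gives a measured number, while the comparison with compound 1, an at least 1.4-fold lower number from compound 1 to compound 4 (0.17 log units; that floor lies within the scatter), establishes no order between the two. Compound 1 remains a limit of the assay: the limit of > 30000 nM in this assay, at which 1 of the 4 values shown sits.

The compounds shown leave open whether the step from formyl to acetyl would be of similar size with chloro in place of the methyl on the aromatic carbon. They also leave open what an amine, a hydroxyl or a longer chain would do in place of the methyl on this carbonyl carbon.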